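From a Sulfamoylphenyl Group to an Ethyl Ester

The source may report more compounds than this note shows. Statements on the series, on what has been measured and on what is new or still open speak of the compounds shown alone.

Compound 3 `CCCCCCCCc1ccc(OCC(=O)Cn2nnnc2-c2cccc(S(=O)(=O)N(C)C)c2)cc1` gives 1900 nM in an assay on microsomes from brain for inhibition of Fatty-acid amide hydrolase 1 (Rattus norvegicus), read by fluorescence and HPLC, with a stated time of 60 min (a higher number here means a weaker inhibitor, a lower number a stronger inhibitor), the highest of the three numbers in this set; compound 2 `CCCCCCCCc1ccc(OCC(=O)Cn2nnnc2-c2ccccc2)cc1` gives 71 nM and compound 1 `CCCCCCCCc1ccc(OCC(=O)Cn2nnc(-c3cccc(Cl)c3)n2)cc1` gives 24 nM. Compound 4 `CCCCCCCCc1ccc(OCC(=O)Cn2nnnc2C(=O)OCC)cc1` differs from compound 3 by ethoxycarbonyl in place of 3-(dimethylsulfamoyl)phenyl on an aromatic carbon. For the measured compounds named here, only one measured step bears on this change: a 27-fold higher number from compound 2 to compound 3 (1.43 log units; beyond the scatter) shows how much the dimethylsulfamoyl group added to the number of compound 2. Going by the values given here, no measured pair exchanges the whole aryl group for an ester, so the expectation rests on that single step and on the removal of the group that weakened compound 3. Compound 4 is therefore expected to give about 150 nM, within a range of 30 nM to 1000 nM. The estimated step of a 13-fold lower number from compound 3 to compound 4 (1.10 log units; beyond the scatter) is expected to lie beyond the scatter, toward a lower number.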

Compound 4, half-maximal inhibitory concentration: 940 nM
Compound 4: the middle estimate sits 6.3-fold (0.80 log units) below what was measured; the measured number falls inside the stated range.
By their numbers in this assay, from the lowest: compound 1; then compound 2; then compound 4; then compound 3.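

Ethoxycarbonyl in place of 3-(dimethylsulfamoyl)phenyl brings only a 2.0-fold lower number from compound 3 to compound 4 (0.31 log units; beyond the scatter) in this assay, so removing that whole group recovers little at this aromatic carbon. Set against the plain phenyl, the same ester gives a 13-fold higher number from compound 2 to compound 4 (1.12 log units; beyond the scatter) and leaves compound 4 far short of compound 2, so the ester does not stand in for phenyl here. No measurement shown here accounts for this gap. Going by these compounds, it remains open how a carboxylic acid, an amide or a methyl group would compare at this carbon. On these data alone, the effect of a longer ester chain is also open.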